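A few compounds are considered here, and "the series" means these few. Any claim that something is new, unique, unknown or untested is made for them only; others in the source may bear on it.

Measured so far in a functional assay (Homo sapiens) for inhibition; on this read-out lower numbers stand for stronger inhibition and higher numbers for weaker inhibition:

- compound 1 `COc1cc(/C=C/C(=O)c2ccc(C3CCCCC3)cc2)cc(OC)c1` gives 39000 nM
- compound 2 `COc1cc(/C=C/C(=O)c2cccc(O)c2)cc(OC)c1` gives 3200 nM
- compound 3 `CCCCOc1ccc(C(=O)/C=C/c2cc(OC)cc(OC)c2)cc1` gives 52000 nM

Compound 3, at 52000 nM, shares the top of this short range with compound 1, and compound 2 has a clearly lower number than either. Next in the series is compound 4 `COc1cc(/C=C/C(=O)c2ccc(O)cc2)cc(OC)c1`, which has hydrogen in place of butyl on an oxygen on an aromatic ring. The group therefore goes from butoxy to hydroxy.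

Going by the values given here, only one step between measured compounds is available, a 1.3-fold higher number from compound 1 to compound 3 (0.12 log units; within the scatter), with butoxy in place of cyclohexyl on an aromatic carbon. It lies within the scatter, but it does not test the loss of the butyl group. Among the compounds with values here, the better guide is compound 2 at 3200 nM, the only measured compound that carries a hydroxy group. Within the data shown here, this is thin support, since no measured pair isolates the change. A lower number beyond the scatter is therefore expected, though with wide uncertainty. The expected step in this assay is an 8.7-fold lower number from compound 3 to compound 4 (0.94 log units; beyond the scatter). For compound 4 the estimated value is 6000 nM, within an expected range of 1500 nM to 25000 nM.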

Compound 4, half-maximal inhibitory concentration: 14000 nM
Compound 4: middle estimate off by 2.3-fold (0.37 log units), on the low side; the measured number falls inside the stated range.
By their numbers in this assay, from the lowest: compound 2; then compound 4; then compounds 1 and 3 (each within the scatter of the next).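

In this assay, the butyl on the oxygen on the aromatic ring is dispensable: its removal gives a 3.7-fold lower number from compound 3 to compound 4 (0.57 log units; beyond the scatter), and the hydroxy group also separates from cyclohexyl with a 2.8-fold lower number from compound 1 to compound 4 (0.44 log units; beyond the scatter), whereas butoxy and cyclohexyl could not be told apart in a 1.3-fold higher number from compound 1 to compound 3 (0.12 log units; within the scatter). The hydroxy group alone does not account for the lowest number in the set, as 4-hydroxyphenyl in place of 3-hydroxyphenyl on the carbonyl carbon gives a 4.4-fold higher number from compound 2 to compound 4 (0.64 log units; beyond the scatter), so the placement of the hydroxy group on this ring matters in this pair. All three new steps are modest, and nothing available gives a measured reason for any of them.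

Going by these compounds, it remains open whether a methoxy group, an amine or a chain shorter than butyl on this ring would fall with the hydroxy compounds or with compound 1 and compound 3. Also open, on these data alone, is whether a butoxy group in the position held by the hydroxy group of compound 2 would give the same step as the one seen on removing butyl from compound 3.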